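Ester Tail Off, Isopropyl On: Cytotoxicity Outlook

The source may hold more compounds than are shown below. What is called first, only, known or untested is meant among the compounds shown, and "the series" means these compounds.

Compound 1 `Cc1ccc2[nH]c(=O)c(CN(Cc3ccc(O)cc3)Cc3ccc(C(C)(C)C)cc3)cc2c1` carries a free hydroxyl on one of its benzyl rings. In a toxicity assay on MDCK cells (Canis lupus familiaris) for cytotoxicity, read by crystal violet staining, with a stated time of 48 h (a lower number here means that less compound is tolerated, a higher number that more compound is tolerated), compound 1 gives 4900 nM. Compound 2 `Cc1ccc2[nH]c(=O)c(CN(Cc3ccc(OCC(=O)OC(C)(C)C)cc3)Cc3ccc(C(C)(C)C)cc3)cc2c1` differs only in that the hydroxyl hydrogen is replaced by a (tert-butoxycarbonyl)methyl group. In this assay compound 2 reaches only the limit of the measurement, > 10000 nM. The step between them was an at least 2.0-fold higher number from compound 1 to compound 2 (0.30 log units; that floor lies within the scatter), and because the limit of > 10000 nM in this assay, at which 1 of the 2 values shown sits, that size is only a floor. Compound 3 `Cc1ccc2[nH]c(=O)c(CN(Cc3ccc(OC(C)C)cc3)Cc3ccc(C(C)(C)C)cc3)cc2c1` is the next variation: isopropyl in place of (tert-butoxycarbonyl)methyl on an oxygen on an aromatic ring. For the measured compounds named here, only the one measured step bears on this change, and it shows that attaching that group to the oxygen did not make the cells tolerate less compound. Replacing most of it with an isopropyl is therefore expected to give an at least 1.1-fold lower number from compound 2 to compound 3 (0.04 log units; that floor lies within the scatter). Compound 3 is estimated at 9000 nM, with a likely range from 4000 nM to 20000 nM.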

Compound 3, half-maximal cytotoxic concentration: > 5000 nM
Compound 3 ended at the assay's limit (the forecaster's own chance of this, stated with the estimate: 45%); the middle value is on the limit's open side.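

With isopropyl on the oxygen in place of hydrogen, the record in this assay reads an at least 1.0-fold higher number from compound 1 to compound 3 (0.00 log units; that floor lies within the scatter). Two quite different groups on this oxygen, (tert-butoxycarbonyl)methyl and isopropyl, have now been tried, and neither shows the cells tolerating less compound than compound 1 does, so the ester part of the tail is not needed for that outcome. The step from compound 2 to compound 3 cannot be read, since each of the two compounds ends at a limit of the assay, and the limit for compound 3 is the lower one: the limit of > 5000 nM in this assay, at which 1 of the 3 values shown sits.

As far as these compounds go, how far the true value of compound 3 lies past its limit stays unknown, so it may match compound 1 or lie well beyond it. From the compounds shown here alone, whether an amine or a carboxylic acid on this oxygen would lower the number also stays open.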